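Removing One Hydroxy From the Trihydroxyphenyl Hydrazone

This account rests on a few compounds, and the source may have more. Where it says the series, first, only, none or still open, it means among the compounds named here.

Three compounds have been measured so far:
Compound 1 `COc1ccccc1-c1nnc(-c2ccc(C(=O)N/N=C/c3ccncc3)cc2)o1` gives 173000 nM
Compound 2 `COc1ccccc1-c1nnc(-c2ccc(C(=O)N/N=C/c3ccc(Cl)cc3Cl)cc2)o1` gives 78800 nM
Compound 3 `COc1ccccc1-c1nnc(-c2ccc(C(=O)N/N=C/c3c(O)cc(O)cc3O)cc2)o1` gives 12400 nM

All three share the same core and differ only in the aryl group attached to the carbon that carries a double bond to nitrogen. In an ADME assay on THP-1 cells (Homo sapiens) for cytotoxicity (on this read-out lower numbers stand for stronger inhibition and higher numbers for weaker inhibition), compound 3 stands lowest of the three numbers. The two steps that lead to it are both beyond the scatter: a 14-fold lower number from compound 1 to compound 3 (1.14 log units; beyond the scatter) and a 6.4-fold lower number from compound 2 to compound 3 (0.80 log units; beyond the scatter). The smaller step of a 2.2-fold lower number from compound 1 to compound 2 (0.34 log units; beyond the scatter) shows that swapping one aryl group for another can move the number modestly.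

Compound 4 `COc1ccccc1-c1nnc(-c2ccc(C(=O)N/N=C/c3ccc(O)cc3O)cc2)o1` is the next to be measured. It differs from compound 3 in one place: hydrogen in place of hydroxy on an aromatic carbon. This is a partial reversal of the change that produced compound 3, since compound 4 keeps two hydroxy groups where compound 3 has three. The two steps into compound 3 suggest that hydroxy groups on this ring go with lower numbers, so taking one away is expected to raise the number by a modest amount, though not all the way back. Compound 4 is therefore estimated at 25000 nM in this assay, within 9000 nM to 70000 nM, an expected step of a 2.0-fold higher number from compound 3 to compound 4 (0.30 log units; within the scatter).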

Compound 4, half-maximal inhibitory concentration: 104000 nM
Beside the measured number, compound 4's estimate is 4.2-fold (0.62 log units) below it; measured number outside the range, above it.
By their numbers in this assay, from the lowest: compound 3; then compounds 2, 4 and 1 (each within the scatter of the next, the first and the last beyond it).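

In this assay, a single hydroxy on this aromatic carbon, ortho to a large group, turns out to matter a great deal: the change to hydrogen gives an 8.4-fold higher number from compound 3 to compound 4 (0.92 log units; beyond the scatter) and undoes nearly all of the advantage that the 2,4,6-trihydroxyphenyl group held over the other aryl groups. Within the data shown here, the two hydroxy groups that remain do not set compound 4 apart, since a 1.3-fold higher number from compound 2 to compound 4 (0.12 log units; within the scatter) and a 1.7-fold lower number from compound 1 to compound 4 (0.22 log units; within the scatter) both leave it within reach of the earlier compounds, so the 2,4-dihydroxyphenyl group cannot be told apart here from either 2,4-dichlorophenyl or pyridin-4-yl. Among these four compounds, then, the number does not fall step by step with each hydroxy added, and the low number belongs only to the complete 2,4,6-trihydroxyphenyl group of compound 3.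

Nothing available explains why this one hydroxy counts for so much. From the compounds shown here alone, it also remains open whether a different group on the same carbon, such as a methoxy or an amine, would keep the low number of compound 3 or lose it as hydrogen does.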